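Swapping the Amide Aryl Group: Estimating Compound 4

A few compounds are considered here, and "the series" means these few. Any claim that something is new, unique, unknown or untested is made for them only; others in the source may bear on it.

Of the compounds shown here, three sharing one long chain have been measured in a functional assay on 143B cells (Homo sapiens) for inhibition, read by MTT assay, with a stated time of 72 h; a lower number here means a stronger inhibitor, a higher number a weaker inhibitor. Compound 1 `Cc1ccccc1NC(=O)CCC(=O)OCCCCCCSc1ccc([N+](=O)[O-])c2nonc12` carries a 2-methylphenyl on its amide nitrogen and gives 4660 nM. Compound 2 `O=C(CCC(=O)OCCCCCCSc1ccc([N+](=O)[O-])c2nonc12)Nc1ccc(Br)cc1` carries a 4-bromophenyl there and gives 2710 nM. Compound 3 `COc1ccc(NC(=O)CCC(=O)OCCCCCCSc2ccc([N+](=O)[O-])c3nonc23)cc1` carries a 4-methoxyphenyl and gives 3060 nM. Among these three, compound 1 stands together with compounds 2 and 3, separated from neither beyond the scatter: the step of a 1.7-fold lower number from compound 1 to compound 2 (0.24 log units; within the scatter) and the step of a 1.5-fold lower number from compound 1 to compound 3 (0.18 log units; within the scatter) are both small, and the step of a 1.1-fold higher number from compound 2 to compound 3 (0.05 log units; within the scatter) is smaller still.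

Compound 4 `O=C(CCC(=O)OCCCCCCSc1ccc([N+](=O)[O-])c2nonc12)Nc1ccc(F)c(Cl)c1` differs from compound 1 in one place: 3-chloro-4-fluorophenyl in place of 2-methylphenyl on an amide-type nitrogen. Among the measured compounds shown here, the steps that bear on this are those from compound 1 to compound 2 and from compound 1 to compound 3, each exchanging the aryl group on the same amide-type nitrogen, and each staying within the scatter. Nothing in these three numbers suggests that the aryl group on that nitrogen moves this assay much. The expectation is therefore a step no larger than the scatter, a 1.4-fold lower number from compound 1 to compound 4 (0.15 log units; within the scatter), and compound 4 is estimated at 3300 nM, with a range from 1500 nM to 7500 nM.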

Compound 4, half-maximal inhibitory concentration: 2990 nM
The estimate for compound 4 lay 1.1-fold (0.04 log units) above the measured number; the measured number falls inside the stated range.
By their numbers in this assay, from the lowest: compounds 2, 4, 3 and 1 (each within the scatter of the next).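

In this assay, a ring carrying both a chlorine and a fluorine on the amide-type nitrogen leaves the number within the scatter of all three earlier compounds: the steps are a 1.6-fold lower number from compound 1 to compound 4 (0.19 log units; within the scatter), a 1.0-fold lower number from compound 3 to compound 4 (0.01 log units; within the scatter) and a 1.1-fold higher number from compound 2 to compound 4 (0.04 log units; within the scatter). Among the compounds shown here, the earlier compounds each carried a single group on the phenyl ring, so this is the first sign that two halogens together, on a group one heavy atom larger than 2-methylphenyl, still produce no step beyond the scatter at this position. All four compounds therefore stand together, and none can be ranked above another, but why this position responds so little cannot be said from these numbers, as nothing measured here bears on it.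

The compounds shown leave open whether a more different group on this nitrogen, such as a phenyl ring bearing a carboxylic acid or an amine, or a cyclohexyl ring in place of the aromatic ring, would produce a step beyond the scatter. Because only this one position varies, they also leave open whether a longer chain elsewhere in the molecule would change the number.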